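This account rests on a few compounds, and the source may have more. Where it says the series, first, only, none or still open, it means among the compounds named here.

Compound 1 `O=C(Nc1cccc(-c2cccc(NC(=O)C(Cl)Cl)c2)c1)C(Cl)Cl`: > 50000 nM
Compound 2 `O=C(Nc1cccc(-c2cccs2)c1)C(Cl)Cl`: > 50000 nM
Compound 3 `CSc1ccccc1-c1cc(NC(=O)C(Cl)Cl)cc(-c2ccccc2SC)c1`: > 30000 nM

Of the compounds shown here, three have been tested in a functional assay on KB 3-1 cells (Homo sapiens) for cytotoxicity, read by MTT assay, with a stated time of 68 h; a lower number here means a stronger inhibitor, a higher number a weaker inhibitor. Compound 1 gives > 50000 nM, which is a limit of the assay and not a measured number. Compound 2 gives > 50000 nM, likewise a limit. Compound 3 gives > 30000 nM, again a limit. Within the data shown here, compound 1 therefore stands where every compound measured so far stands: no number has been reached, two of the three values sit at the limit of > 50000 nM in this assay, at which 2 of the 3 values shown sit, and one at the limit of > 30000 nM in this assay, at which 1 of the 3 values shown sits. Among the measured compounds shown here, no step between two measured compounds is known, so the size of any change cannot be read from these data.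

Compound 4 `COc1cccc(-c2cccc(NC(=O)C(Cl)Cl)c2)c1` is not yet measured. It differs from compound 1 in one place: methoxy in place of ((dichloromethyl)carbonyl)amino on an aromatic carbon. Since compound 1 and both its companions show only limits in this assay, there is no ground to expect a move into the measurable range. The step from compound 1 to compound 4 in this assay is expected to be a number no higher from compound 1 to compound 4 (the limit leaves the size open), that is, none beyond the scatter. Compound 4 is therefore expected to give about 50000 nM in this assay, with a range from 20000 nM to 100000 nM, and most likely only a limit will be reported once more.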

Compound 4, half-maximal inhibitory concentration: 43300 nM
Beside the measured number, compound 4's estimate is 1.2-fold (0.06 log units) above it; the measured number falls inside the stated range.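

In this assay, compound 4 gives 43300 nM, the only real number among the compounds shown, so this series can give a reading once methoxy stands in place of ((dichloromethyl)carbonyl)amino on this aromatic carbon. The change gives an at least 1.1-fold lower number from compound 1 to compound 4 (0.06 log units; that floor lies within the scatter), which means that a second ((dichloromethyl)carbonyl)amino group is not needed for a reading at this level, although a number this high still marks a weak inhibitor. From the compounds shown here alone, the true size of the step stays open because compound 1 shows only a limit and not a number: the limit of > 50000 nM in this assay, at which 2 of the 4 values shown sit.

With methoxy as the only replacement shown at this position, it remains unclear whether methoxy itself matters or whether simply removing the larger group is enough, and a hydroxyl group, an amine or a carboxylic acid on the same aromatic carbon would help to tell these apart. Also open is what the ((dichloromethyl)carbonyl)amino group that compound 4 keeps contributes to its reading, since no compound shown differs from compound 4 at that group alone.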